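Trimming Ethyl to Methyl: Cytotoxicity Limit Expected to Persist

A few compounds are considered here, and "the series" means these few. Any claim that something is new, unique, unknown or untested is made for them only; others in the source may bear on it.

compound 1 `CN(C)C(=S)SC(=S)N1CCCCC1` gives > 5000000 nM
compound 2 `CCN(CC)C(=S)SC(=S)N(C)C` gives > 5000000 nM

Both measured compounds were run in an ADME assay on HeLa cells (Homo sapiens) for cytotoxicity, read by MTT assay, with a stated time of 24 h; a lower number here means a stronger inhibitor, a higher number a weaker inhibitor. For compound 1 the reported figure is a limit of the assay rather than a number, namely > 5000000 nM. For compound 2 the reported figure is likewise a limit of the assay and not a number, namely > 5000000 nM. Compound 2 therefore stands at the limit of > 5000000 nM in this assay, at which 2 of the 2 values shown sit, and no order between compound 1 and compound 2 can be drawn from these figures.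

Compound 3, `CCN(C)C(=S)SC(=S)N(C)C`, differs from compound 2 in one place: hydrogen in place of methyl on a saturated chain carbon bound to an amide-type nitrogen. Among the compounds with values here, no pair of measured compounds differing in a single place is available, so no measured step size exists in this assay to lean on.

The expected change from compound 2 to compound 3 is a number no higher from compound 2 to compound 3 (the limit leaves the size open), that is, none beyond the usual scatter. Compound 3 is accordingly estimated at 5000000 nM, with a range from 2000000 nM to 20000000 nM, and it is expected that this assay will most likely again report only a limit for compound 3.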

Compound 3, half-maximal inhibitory concentration: 2070000 nM
For compound 3 the middle estimate is 2.4-fold (0.38 log units) above the measured one; the measured number falls inside the stated range.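

In this assay, compound 3 is the first compound shown to give a number rather than a limit, so this position on the chain can shift the read-out. Hydrogen in place of methyl on a saturated chain carbon bound to an amide-type nitrogen, which also reads as ethyl to methyl, gives an at least 2.4-fold lower number from compound 2 to compound 3 (0.38 log units; beyond the scatter), and this size is only a lower bound since compound 2 is reported as a limit, not a number. Within the data shown here, that limit remains the most common reading in this small set, and only this one change has moved a compound away from it: the limit of > 5000000 nM in this assay, at which 2 of the 3 values shown sit.

As far as these compounds go, it remains open whether a second trim of ethyl to methyl would lower the number again, or whether a propyl chain or an amine-bearing chain at this place would return the reading to the limit. Compound 1 differs from compound 3 in more than one place, so the compounds shown do not say how the group it carries in place of the ethyl-bearing end would behave in a single-place comparison.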